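The compounds below may be only part of what the source reports. "The series", "measured", "known", "first", "only" and "open" are said of these compounds alone.

Measured so far in a functional assay, with a stated time of 30 min; a higher number here means a weaker inhibitor, a lower number a stronger inhibitor:

- compound 1 `COc1cc(CN(CCCO)Cc2ccc(O)c(OC)c2)ccc1O`: 13700 nM
- compound 2 `COc1cc(CN(CCCCCO)Cc2ccc(O)c(OC)c2)ccc1O`: 24000 nM
- compound 3 `COc1cc(CN(CCCCCCO)Cc2ccc(O)c(OC)c2)ccc1O`: 22200 nM

Compound 1 holds the lowest of the three numbers, but neither of the other two is separated from it by more than the scatter: a 1.8-fold higher number from compound 1 to compound 2 (0.24 log units; within the scatter) and a 1.6-fold higher number from compound 1 to compound 3 (0.21 log units; within the scatter). The two longer-chain compounds sit on top of one another, a 1.1-fold lower number from compound 2 to compound 3 (0.03 log units; within the scatter). Across the set, the length of the hydroxyalkyl chain on the amine nitrogen makes no difference that can be trusted in this assay.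

Compound 4 `CCCCN(Cc1ccc(O)c(OC)c1)Cc1ccc(O)c(OC)c1` differs from compound 1 in one place: methyl in place of hydroxy on a saturated chain carbon, three bonds along the chain from an amine nitrogen. Within the data shown here, none of the measured steps touches the hydroxy itself; each of them only moves it further out along the chain, and each stays within the scatter. Among the measured compounds shown here, there is therefore no direct precedent for taking the hydroxy away. What the series does show is that this assay is insensitive to how the chain carrying the hydroxy is built, which argues against a large step in either direction from removing it. On these data alone, the number for compound 4 is expected to stay close to that of compound 1, with a step of a 1.2-fold higher number from compound 1 to compound 4 (0.07 log units; within the scatter) that should not clear the scatter, and a wide range is kept because the change is untested. Compound 4 is estimated at 16000 nM, between 6000 nM and 45000 nM.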

Compound 4, half-maximal inhibitory concentration: 21900 nM
Compound 4: the middle estimate sits 1.4-fold (0.14 log units) below what was measured, and the stated range covers the measured number.
By their numbers in this assay, from the lowest: compounds 1, 4, 3 and 2 (each within the scatter of the next).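

Among these compounds, replacing hydroxy with methyl, on a saturated chain carbon, three bonds along the chain from an amine nitrogen, is the first change that removes the hydroxy rather than moving it along the chain, and in this assay it stays inside the scatter (a 1.6-fold higher number from compound 1 to compound 4 (0.20 log units; within the scatter)), so this read-out does not separate the hydroxy-bearing propyl chain from the butyl chain. Compound 4 also cannot be told apart from the two longer hydroxyalkyl compounds (a 1.0-fold lower number from compound 3 to compound 4 (0.01 log units; within the scatter); a 1.1-fold lower number from compound 2 to compound 4 (0.04 log units; within the scatter)), and all four compounds therefore form one group with no order that can be trusted, whether or not the chain ends in hydroxy. No accompanying measurement is available to explain this flat response.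

On these data alone, whether any chain end can move the number remains open, as a carboxylic acid or an amine at the end of the chain could behave differently from hydroxy and methyl. Also open, as far as these compounds go, is whether the same flat response would hold for changes to the shared core, which all four compounds carry unchanged.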